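A few compounds are considered here, and "the series" means these few. Any claim that something is new, unique, unknown or untested is made for them only; others in the source may bear on it.

In a functional assay on NCI-H292 cells (Homo sapiens) for antiproliferative activity (on this read-out higher numbers stand for weaker inhibition and lower numbers for stronger inhibition), compound 2 `Cc1ccc(N2C(=O)N/C(=C\c3ccc(O)cc3)C2=O)cc1` gives 27900 nM, the highest of the two numbers shown. Its nearest neighbour is compound 1 `O=C1N/C(=C\c2ccc(O)cc2)C(=O)N1c1ccc(I)cc1`, which in this assay gives 25500 nM, the two being separated by a 1.1-fold higher number from compound 1 to compound 2 (0.04 log units; within the scatter). Compound 3 `Cc1cccc(N2C(=O)N/C(=C\c3ccc(O)cc3)C2=O)c1` reaches only a limit of this assay, > 200000 nM, and this is the limit of > 200000 nM in this assay, at which 1 of the 3 values shown sits. The gaps to compound 3 are given by an at least 7.1-fold higher number from compound 2 to compound 3 (0.85 log units; beyond the scatter) and an at least 7.8-fold higher number from compound 1 to compound 3 (0.89 log units; beyond the scatter).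

Compound 4 `CCOC(=O)c1ccc(N2C(=O)N/C(=C\c3ccc(O)cc3)C2=O)cc1` has not yet been measured. It differs from compound 2 by ethoxycarbonyl in place of methyl on an aromatic carbon. Within the data shown here, the only measured step that exchanges groups at that same place is a 1.1-fold higher number from compound 1 to compound 2 (0.04 log units; within the scatter), where iodo gave way to methyl without a change beyond the scatter; the steps that lead to compound 3 replace one methylphenyl with another on the amide-type nitrogen in the ring and so bear less directly on this change. The expectation for compound 4 in this assay is therefore a step of a 1.1-fold higher number from compound 2 to compound 4 (0.03 log units; within the scatter), meaning little change beyond the scatter. Compound 4 is estimated to give 30000 nM, with a range from 10000 nM to 100000 nM.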

Compound 4, half-maximal inhibitory concentration: > 200000 nM
Compound 4: only a limit was reported; the forecaster's own chance of this, stated with the estimate: 15%; middle value at least 6.6-fold (0.82 log units) away from the limit.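

In this assay compound 4 gives > 200000 nM, which is a limit and not a number. The exchange of iodo for methyl had suggested that this aromatic carbon, para to a large group, tolerates change, but it does not tolerate every group: ethoxycarbonyl in place of methyl gives an at least 7.1-fold higher number from compound 2 to compound 4 (0.85 log units; beyond the scatter), and ethoxycarbonyl in place of iodo gives an at least 7.8-fold higher number from compound 1 to compound 4 (0.89 log units; beyond the scatter). A change of the group at this place thus ends at the same reading as the shift of methyl in compound 3: the limit of > 200000 nM in this assay, at which 2 of the 4 values shown sit.

With only iodo, methyl and ethoxycarbonyl at this place, the compounds shown do not tell whether a carboxylic acid, an amine or a plain ethyl chain there would stay level with compound 2 or also reach the limit. Nor do they tell whether the ester as a whole or only its length decides the outcome.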